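A few compounds are considered here, and "the series" means these few. Any claim that something is new, unique, unknown or untested is made for them only; others in the source may bear on it.

Measured so far:
compound 1, `O=C(NCc1ccc(F)cc1)c1nc(Br)c2cccnc2c1NCc1ccccc1`: "not determined" (no result reported)
compound 2, `C[C@H](CO)Nc1nc(C(=O)NCc2ccc(F)cc2)c(O)c2ncccc12`: 69000 nM

Compound 1 stands without a single number in a toxicity assay on C8166 cells (Homo sapiens) for cytotoxicity, read by MTT assay, with a stated time of 72 h (a lower number here means that less compound is tolerated, a higher number that more compound is tolerated), so its tolerance is open. Compound 2 shares the core and in this assay gives 69000 nM. Compound 3 `O=C(NCc1ccc(F)cc1)c1nc(Br)c2cccnc2c1NCCO` has not yet been measured. It differs from compound 1 by hydroxymethyl in place of phenyl on a saturated chain carbon bound to a nitrogen on an aromatic ring. With no number for compound 1, no step size can be read from the data; the change is expected to move tolerance by no more than the scatter, in no set direction. Given that compound 2 gives 69000 nM, compound 3 is expected near 80000 nM, between 25000 nM and 250000 nM.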

Compound 3, half-maximal cytotoxic concentration: 232000 nM
Compound 3: the middle estimate sits 2.9-fold (0.46 log units) below what was measured; low and high end bracket the measured number.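

No step can be read between compound 1 and compound 3 in this assay: compound 1 has no single number there. On these data alone, what exchanging phenyl for hydroxymethyl does to tolerance stays open. No evidence bears on this result.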